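The compounds below may be only part of what the source reports. "The series", "measured", "known", "first", "only" and "open" are said of these compounds alone.

In an assay on isolated protein for inhibition of Rho-associated protein kinase 1 (Homo sapiens), tested at 30 uM (a higher number here means more inhibition at the concentration tested (going by the name of the read-out), a lower number less inhibition), three compounds have been measured so far. Compound 1 `Cn1cnc2c(Nc3ccc(F)cc3)ncnc21` gives 7%, compound 2 `Fc1ccc(Sc2ncnc3[nH]cnc23)cc1` gives 37%, and compound 3 `Fc1ccc(Sc2[nH]cnc3nccc2-3)cc1` gives 42%. Compound 2 stands second highest of the three: its number sits close to that of compound 3, within the usual scatter, and well above that of compound 1, beyond the scatter. Compound 4 `Cn1cnc2c(Sc3ccc(F)cc3)ncnc21` has not yet been tested in this assay. It differs from compound 2 in one place: methyl in place of hydrogen on an aromatic nitrogen. Going by the values given here, no measured pair shows this change alone, so its size is open. Compound 1 also carries a methyl on a ring nitrogen, and in this assay compound 1 gives 7%, though it differs from compound 4 elsewhere too. Compound 4 is therefore estimated at 20%, with a likely range from 5% to 40%. The expected step of a number 17 percentage points lower from compound 2 to compound 4 (beyond the scatter) is a drop that would probably reach beyond the scatter.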

Compound 4, a percentage reported as inhibition, at one concentration (the size of the read-out at that concentration, not a potency): 6%
Estimate against measurement, compound 4: 14 percentage points above, and the stated range covers the measured number.
By their numbers in this assay, from the lowest: compounds 4 and 1 (each within the scatter of the next); then compounds 2 and 3 (each within the scatter of the next).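

In this assay, going by these compounds alone, this pair gives the first direct reading of this ring nitrogen: putting a methyl in place of its hydrogen gives a number 31 percentage points lower from compound 2 to compound 4 (beyond the scatter). So on this core, one added carbon at this position removes most of the inhibition. Nothing available explains this drop.

Still open is whether any group can be placed on this nitrogen, since only methyl is shown here. An ethyl group or a longer chain ending in an amine could show whether inhibition falls further or returns.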